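Sulfonamide series: fluoro for hydrogen on the phenyl

This account rests on a few compounds, and the source may have more. Where it says the series, first, only, none or still open, it means among the compounds named here.

Measured in a functional assay on HCC827 cells (Homo sapiens) for cytotoxicity, read by MTT assay, with a stated time of 48 h; a lower number here means a stronger inhibitor, a higher number a weaker inhibitor:
Compound 1 `COc1cc2c(Oc3ccc(NC(=O)c4c(C)n(C)n(-c5ccccc5)c4=O)cc3F)ccnc2cc1OCCCN1CCN(C)CC1` gives 2580 nM.
Compound 2 `COc1cc2c(Oc3ccc(NS(=O)(=O)c4cccc(-c5cnn(C)c5)c4)cc3F)ccnc2cc1OCCCN1CCN(C)CC1` gives 2830 nM.
Compound 3 `COc1cc2c(Oc3ccc(NS(=O)(=O)c4cccc(-c5ccsc5)c4)cc3F)ccnc2cc1OCCCN1CCN(C)CC1` gives 1940 nM.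

Compound 3 has the lowest of the three numbers in this assay, but its gaps to compound 1 and to compound 2 both lie within the scatter, so no order among the three can be drawn. Among the compounds with values here, the only single-point step, a 1.5-fold lower number from compound 2 to compound 3 (0.16 log units; within the scatter), is likewise within the scatter. Compound 4 `COc1cc2c(Oc3ccc(NS(=O)(=O)c4cc(-c5ccsc5)ccc4F)cc3F)ccnc2cc1OCCCN1CCN(C)CC1` differs from compound 3 by fluoro in place of hydrogen on an aromatic carbon. Within the data shown here, no measured step touches a fluoro-for-hydrogen exchange on this ring, and the one step known is within the scatter; the data give no direction. The expectation for compound 4 in this assay is therefore no step beyond the scatter, a 1.0-fold lower number from compound 3 to compound 4 (0.01 log units; within the scatter). Compound 4 is estimated at 1900 nM, range 900 nM to 4000 nM.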

Compound 4, half-maximal inhibitory concentration: 2820 nM
Compound 4: middle estimate off by 1.5-fold (0.17 log units), on the low side; low and high end bracket the measured number.
By their numbers in this assay, from the lowest: compounds 3, 1, 4 and 2 (each within the scatter of the next).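

In this assay, within the data shown here, fluoro on this ring, ortho to a large group and para to a thiophen-3-yl group, gives a 1.5-fold higher number from compound 3 to compound 4 (0.16 log units; within the scatter), so the only hydrogen exchange measured on this ring cannot be told from the scatter. The wider change gives a 1.0-fold lower number from compound 2 to compound 4 (0.00 log units; within the scatter), also within the scatter, so swapping 3-(1-methyl-1H-pyrazol-4-yl)phenyl for 2-fluoro-5-(thiophen-3-yl)phenyl shows no measurable effect in this assay. Nothing available bears on a cause for either result.

On these data alone, whether chloro, methoxy or an amine on this carbon would give a step beyond the scatter stays open. So does the effect of fluoro on the other carbons of this ring.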